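Swapping the Aryl Cap on a Piperazine Amide

The source may report more compounds than this note shows. Statements on the series, on what has been measured and on what is new or still open speak of the compounds shown alone.

This short series shares a core in which a methyl-bearing oxazole amide is joined to a piperazine carrying an aromatic cap, and it is tested in a functional assay on HL-60 cells (Homo sapiens) for inhibition, read by MTT assay, with a stated time of 72 h; on this read-out lower numbers stand for stronger inhibition and higher numbers for weaker inhibition. Compound 1, `C=C(C)c1cccc(N2CCN(C(=O)c3oc(C)nc3-c3ccccc3F)CC2)c1`, carries a fluorine-bearing phenyl on the oxazole and an isopropenylphenyl cap. In this assay compound 1 is reported as "not active" (no number reported). Compound 2, `Cc1nc(-c2ccccc2)c(C(=O)N2CCN(c3ccc(C(F)(F)F)cc3)CC2)o1`, differs in both places and carries a 4-(trifluoromethyl)phenyl cap. In this assay compound 2 gives > 1000 nM, which is a limit of the assay and not a measured number. Compound 2 thus stands at the limit of > 1000 nM in this assay, at which 1 of the 2 values shown sits, with nothing in the set to rank it against, since the only other entry carries no number either.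

Compound 3, `Cc1cc(C)cc(N2CCN(C(=O)c3oc(C)nc3-c3ccccc3)CC2)c1`, is the next step: 3,5-dimethylphenyl in place of 4-(trifluoromethyl)phenyl on an amine nitrogen in a ring. For the measured compounds named here, no measured step exists between compounds here, so the expected step that the limit leaves unreadable from compound 2 to compound 3 is essentially none beyond the scatter, with the limit still the most likely outcome. Compound 3 is therefore expected to give about 3000 nM, within a range from 700 nM to 20000 nM.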

Compound 3, half-maximal inhibitory concentration: 34.5 nM
The estimate for compound 3 lay 87-fold (1.94 log units) above the measured number; the measured number lies below the stated range.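

For the compounds shown here, with 3,5-dimethylphenyl as the aryl group on the piperazine, compound 3 gives 34.5 nM in this assay, the first actual number. Compound 3 and compound 2 share the same core and differ only in this cap, so the change at this amine nitrogen alone accounts for an at least 28-fold lower number from compound 2 to compound 3 (1.46 log units; beyond the scatter), which shows that the choice of cap here can separate a compound with a measurable number from one without. Compound 2 gives > 1000 nM, a limit of the assay and not a number, and the full size of the step stays unknown because of it: the limit of > 1000 nM in this assay, at which 1 of the 3 values shown sits.

Going by these compounds, compound 1 differs from both compound 2 and compound 3 in more than one place, so steps involving it cannot be read, and the separate contribution of its fluorine-bearing phenyl or its isopropenylphenyl cap stays unknown. The compounds shown also leave open whether both methyl groups of the 3,5-dimethylphenyl cap are needed, and whether a cap carrying a methoxy group, a chlorine atom or an amine would keep the number low.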